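The source may hold more compounds than are shown below. What is called first, only, known or untested is meant among the compounds shown, and "the series" means these compounds.

Measured compounds:
- Compound 1, `CC(=O)Nc1ccc(OCc2nnc(SCC(=O)Nc3ccc(S(N)(=O)=O)cc3)n2Cc2ccccc2)cc1`. In a toxicity assay on MT4 cells (Homo sapiens) for cytotoxicity, read by MTT assay, with a stated time of 5 days (a higher number here means that more compound is tolerated, a lower number that less compound is tolerated), compound 1 gives > 125 ug/mL, which is a limit of the assay rather than a number.
- Compound 2, `CC(=O)Nc1ccc(OCc2nnc(SCC(=O)Nc3ccc(Br)cc3)n2Cc2ccccc2)cc1`. Compound 2 gives >= 3.99 ug/mL, again a limit rather than a number.
- Compound 3, `NS(=O)(=O)c1ccc(NC(=O)CSc2nnc(COc3ccc4ccccc4c3)n2Cc2ccccc2)cc1`. Compound 3 gives 94.5 ug/mL.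

Among the compounds with values here, compound 3 therefore stands as the only compound of the three with an actual number in this assay; the other two values are limits. From compound 1 to compound 3 the change was naphthalen-2-yl in place of 4-acetamidophenyl on an oxygen on a saturated carbon, and the step was an at least 1.3-fold lower number from compound 1 to compound 3 (0.12 log units; that floor lies within the scatter).

Compound 4, `O=C(CSc1nnc(COc2ccc3ccccc3c2)n1Cc1ccccc1)Nc1ccc(Br)cc1`, has not yet been measured. It differs from compound 3 in one place: bromo in place of sulfamoyl on an aromatic carbon. The same exchange has been seen once before, from compound 1 to compound 2, but that step is a step that the two limits leave unreadable from compound 1 to compound 2, so it gives no readable size. The expectation for compound 4 thus rests on little, and the step is estimated as a 1.6-fold lower number from compound 3 to compound 4 (0.20 log units; within the scatter), with wide uncertainty. Compound 4 is expected to give about 60 ug/mL, within a range from 15 ug/mL to 125 ug/mL.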

Compound 4, half-maximal cytotoxic concentration: 58.1 ug/mL
Compound 4: middle estimate off by 1.0-fold (0.01 log units), on the high side; low and high end bracket the measured number.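

Bromo in place of sulfamoyl on an aromatic carbon, para to a large group, now has a size that can be read: in this assay the result is a 1.6-fold lower number from compound 3 to compound 4 (0.21 log units; within the scatter). With naphthalen-2-yl on the oxygen, then, a sulfamoyl group of 4 heavy atoms, with a hydrogen-bond donor and hydrogen-bond acceptors, and a single bromine atom give values that cannot be told apart in this assay. Compound 1, which carries 4-acetamidophenyl on the oxygen, offers no number to compare, only a limit of the assay: the limit of > 125 ug/mL in this assay, at which 1 of the 4 values shown sits.

Compound 2 likewise has only a limit of the assay rather than a number, so all the steps that involve it cannot be read: the limit of >= 3.99 ug/mL in this assay, at which 1 of the 4 values shown sits. From the compounds shown here alone, it therefore remains open whether the exchange reads the same with 4-acetamidophenyl on the oxygen, and whether another group at this place on the ring, such as an amine or a carboxylic acid, would also stay within the scatter of compound 3 and compound 4.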